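The source may hold more compounds than are shown below. What is called first, only, known or untested is meant among the compounds shown, and "the series" means these compounds.

Of the compounds shown here, three have been measured in a functional assay on the whole organism for antagonist activity, with Rattus norvegicus as the target; on this read-out lower numbers stand for an effect already at smaller amounts and higher numbers for an effect only at larger amounts of compound. Compound 1 `c1nc(NC2CC2)c2ncn(CC3CCC3)c2n1` gives 10 mg/kg, compound 2 `CC(C)n1cnc2c(NC3CC3)ncnc21` gives 4 mg/kg, and compound 3 `CCCCn1cnc2c(NC3CC3)ncnc21` gives 18 mg/kg. Compound 3 thus shows the highest number of the three: its gap to compound 1 is within the scatter, while the step of a 4.5-fold higher number from compound 2 to compound 3 (0.65 log units; beyond the scatter) lies beyond it. Compound 4 `CC(C)Cn1cnc2c(NC3CC3)ncnc21` has not yet been measured. It differs from compound 3 by isopropyl in place of propyl on a saturated chain carbon bound to an aromatic nitrogen. The step that bears most on this change is a 4.5-fold higher number from compound 2 to compound 3 (0.65 log units; beyond the scatter), where isopropyl on the aromatic nitrogen went with the lower number, and the step of a 2.5-fold lower number from compound 1 to compound 2 (0.40 log units; beyond the scatter) points the same way. The step of a 1.8-fold higher number from compound 1 to compound 3 (0.26 log units; within the scatter) is within the scatter and says little. Compound 4 carries isobutyl, a group related to the isopropyl of compound 2 and to the butyl of compound 3. A modest move toward lower numbers is therefore expected, a 2.0-fold lower number from compound 3 to compound 4 (0.30 log units; within the scatter). Compound 4 is estimated at 9 mg/kg, with a range from 4 mg/kg to 20 mg/kg.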

Compound 4, dose for half-maximal effect: 10 mg/kg
For compound 4 the middle estimate is 1.1-fold (0.05 log units) below the measured one; measured number inside the range.
By their numbers in this assay, from the lowest: compound 2; then compounds 1, 4 and 3 (each within the scatter of the next).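

The new step, a 1.8-fold lower number from compound 3 to compound 4 (0.26 log units; within the scatter), shows that in this assay the change from butyl to isobutyl on the aromatic nitrogen makes no clear difference. Isobutyl also matches the cyclobutylmethyl group of compound 1, with no change at the digits printed from compound 1 to compound 4 (within the scatter) as the step, so the propyl, isopropyl and cyclobutyl ends on this saturated chain carbon cannot be told apart here. Only isopropyl placed directly on the aromatic nitrogen stands apart, as a 2.5-fold higher number from compound 2 to compound 4 (0.40 log units; beyond the scatter) shows, and among these four compounds the one clear difference is whether that chain carbon is present.

Nothing measured here explains this pattern. Going by these compounds, it remains open whether a longer chain such as pentyl, or a chain ending in an amine, would stay close to compound 4 or move away from it.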